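A 4-hydroxybutyl extension on compound 2

The compounds below may be only part of what the source reports. "The series", "measured", "known", "first", "only" and "open" are said of these compounds alone.

In a functional assay, read by fluorescence and spectrophotometry, with a stated time of 1 h (on this read-out higher numbers stand for an effect only at larger amounts of compound and lower numbers for an effect already at smaller amounts), compound 1 (`CCCCCCS(=O)(=O)/C=C/c1ccc(O)c(O)c1`) gives 7300 nM and compound 2 (`CCCCCCCS(=O)(=O)/C=C/c1ccc(O)c(O)c1`) gives 7100 nM, so the two stand level within the scatter. Compound 3 (`O=S(=O)(/C=C/c1ccc(O)c(O)c1)CCCCCCCCCCCO`) differs from compound 2 by 4-hydroxybutyl in place of hydrogen on a saturated chain carbon, seven bonds along the chain from a sulfonyl sulfur. For the measured compounds named here, the only measured step, a 1.0-fold lower number from compound 1 to compound 2 (0.01 log units; within the scatter), involved a single methyl and offers limited guidance. An estimated 1.1-fold lower number from compound 2 to compound 3 (0.04 log units; within the scatter) is therefore expected, with no step beyond the scatter in this assay as the best guess. Compound 3 is expected at 6500 nM, with an estimated range of 2500 nM to 17000 nM here.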

Compound 3, half-maximal effective concentration: 22600 nM
For compound 3 the middle estimate is 3.5-fold (0.54 log units) below the measured one, outside the stated range (above it).
By their numbers in this assay, from the lowest: compounds 2 and 1 (each within the scatter of the next); then compound 3.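

In this assay this position proved sensitive to change, which the single methyl step had not shown: 4-hydroxybutyl in place of hydrogen gives a 3.2-fold higher number from compound 2 to compound 3 (0.50 log units; beyond the scatter), and the change counted from the shorter chain, 5-hydroxypentyl in place of hydrogen, gives a 3.1-fold higher number from compound 1 to compound 3 (0.49 log units; beyond the scatter). Nothing available accounts for this shift.

The added carbons and the hydroxyl arrive together, so the compounds shown cannot assign the shift to either. A longer chain without the hydroxyl, or an amine or a carboxylic acid in its place, would remain to be compared.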